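The source may report more compounds than this note shows. Statements on the series, on what has been measured and on what is new or still open speak of the compounds shown alone.

Of the compounds shown here, three sharing one core have been measured in an assay for inhibition of high affinity nerve growth factor receptor (Homo sapiens), read by HTRF, with a stated time of 30 min, in the presence of a further agent that is not named here; a higher number here means a weaker inhibitor, a lower number a stronger inhibitor. Compound 1 `Cc1cc(Nc2nc(NCc3ccc(F)cc3)nc3ccccc23)n[nH]1` gives 20 nM, compound 2 `Cc1ccc(CNc2nc(Nc3cc(C)[nH]n3)c3ccccc3n2)cc1` gives 110 nM, and compound 3 `Cc1cc(Nc2nc(NCc3ccc(OC(F)(F)F)cc3)nc3ccccc23)n[nH]1` gives 4100 nM. Compound 2 therefore stands second highest of the three numbers: its nearest neighbour is compound 1, with a 5.5-fold higher number from compound 1 to compound 2 (0.74 log units; beyond the scatter), and its furthest is compound 3, with a 37-fold higher number from compound 2 to compound 3 (1.57 log units; beyond the scatter). The widest gap in the set is a 210-fold higher number from compound 1 to compound 3 (2.31 log units; beyond the scatter).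

Compound 4 `Cc1cc(Nc2nc(NCc3cc(F)ccc3F)nc3ccccc23)n[nH]1` has not yet been measured. It differs from compound 2 by 2,5-difluorophenyl in place of 4-methylphenyl on a saturated chain carbon bound to a nitrogen on an aromatic ring. For the measured compounds named here, none of the measured steps makes exactly this change; each of them swaps a single group on an aromatic carbon, and they show that the benzyl end of the molecule is sensitive, with steps ranging from modest to large. Fluorine on that ring gave the lowest number seen, in compound 1, while the bulkier trifluoromethoxy in compound 3 gave the highest. Since compound 4 carries two fluorines and no methyl, the number for compound 4 is expected to fall between those of compound 2 and compound 1, giving an estimated 2.8-fold lower number from compound 2 to compound 4 (0.44 log units; beyond the scatter). Compound 4 is thus expected to show about 40 nM, within a range from 8 nM to 200 nM.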

Compound 4, half-maximal inhibitory concentration: 7.5 nM
The estimate for compound 4 lay 5.3-fold (0.73 log units) above the measured number; the whole stated range lies above it.
By their numbers in this assay, from the lowest: compound 4; then compound 1; then compound 2; then compound 3.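

For the compounds shown here, compound 4 is the first compound in which the whole benzyl ring changes rather than a single group on an aromatic carbon, and in this assay the exchange of 4-methylbenzyl for 2,5-difluorobenzyl gives a 15-fold lower number from compound 2 to compound 4 (1.17 log units; beyond the scatter). The result also shows that the low number of compound 1 was not a floor for this position, since the change from 4-fluorophenyl to 2,5-difluorophenyl gives a 2.7-fold lower number from compound 1 to compound 4 (0.43 log units; beyond the scatter), so a ring with fluorine on two of its carbons can do better here than the ring with one. The compounds shown offer no independent evidence on why either step goes in this direction.

Because compound 4 differs from compound 1 both in the number of fluorines and in where they stand on the ring, the compounds shown cannot separate those two contributions to its lower number. Going by these compounds, it also remains open how this position would respond to chlorine atoms or a nitrile on the ring, or to a longer chain between the ring and the nitrogen on the aromatic ring.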